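A few compounds are considered here, and "the series" means these few. Any claim that something is new, unique, unknown or untested is made for them only; others in the source may bear on it.

In an assay on isolated protein (Oryctolagus cuniculus) for inhibition of glycogen phosphorylase, brain form (Homo sapiens) (on this read-out higher numbers stand for weaker inhibition and lower numbers for stronger inhibition), compound 1, the structure `[N-]=[N+]=NC[C@H]1O[C@H](CO)[C@@H](O)[C@H](O)[C@H]1O`, gives 22400000 nM, the highest of the three numbers in hand. Compound 3 is the epimer `[N-]=[N+]=NC[C@@H]1O[C@H](CO)[C@@H](O)[C@H](O)[C@H]1O`; compound 3 gives 15200000 nM, and the step of a 1.5-fold lower number from compound 1 to compound 3 (0.17 log units; within the scatter); one configuration is drawn in compound 1 and the other in compound 3 at the place where they differ (the fact that one of compounds 1 and 3 is drawn with a defined configuration and the other without, at the place where they differ). Compound 2, the anilide `O=C(Nc1ccccc1)C1OC(CO)C(O)C(O)C1O`, gives 5400000 nM in this assay, a lower number than compound 1, though no single change links the two.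

Compound 4 is `NC(=O)N[C@H]1O[C@H](CO)[C@@H](O)[C@H](O)[C@H]1O`. It differs from compound 1 in that ureido in place of azidomethyl on a saturated ring carbon. Within the data shown here, no measured step covers this exchange; the only step in hand, from compound 1 to compound 3, concerns a drawn configuration and lies within the scatter, so it sets no direction here. Compound 2 alone hints that a carbonyl-bearing substituent can go with a lower number. Compound 4 is therefore expected to give an estimated 600000 nM, in the range 80000 nM to 5000000 nM, which would be an expected step of a 37-fold lower number from compound 1 to compound 4 (1.57 log units; beyond the scatter).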

Compound 4, inhibition constant: 140000 nM
Estimate against measurement, compound 4: 4.3-fold (0.63 log units) above, within the range that was stated.
By their numbers in this assay, from the lowest: compound 4; then compound 2; then compounds 3 and 1 (each within the scatter of the next).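

In this assay, among these compounds, ureido in place of azidomethyl on a saturated ring carbon, next to the ring oxygen, gives a 160-fold lower number from compound 1 to compound 4 (2.20 log units; beyond the scatter), whereas the only earlier step, a 1.5-fold lower number from compound 1 to compound 3 (0.17 log units; within the scatter), gave this position no direction. The number at this ring carbon therefore responds strongly to the group it carries, even though both groups count 4 heavy atoms; the entering ureido has 2 hydrogen-bond donors and the leaving azidomethyl has 0. Nothing in hand bears on why the number falls so far.

The compounds shown leave open which part of the ureido goes with the step, a question that a simple amine, an acetamido group or a carboxylic acid at this ring carbon could address. They also leave open whether a longer chain on the ureido would keep it, and how the opposite configuration at this ring carbon would read with ureido in place.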